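Replacing an acetyl group on the most active compound

The source may hold more compounds than are shown below. What is called first, only, known or untested is meant among the compounds shown, and "the series" means these compounds.

Measured in a functional assay on U-87MG ATCC cells (Homo sapiens) for antiproliferative activity; on this read-out higher numbers stand for weaker inhibition and lower numbers for stronger inhibition:
- compound 1 `Cc1c2c(n3c1CCCNC[C@H](C)Nc1cc-3ccc1C(N)=O)CC(C)(C)CC2=O`: 366 nM
- compound 2 `Cc1c2c(n3c1CCCN[C@@H](C)[C@H](C)Nc1cc-3ccc1C(N)=O)CC(C)(C)CC2=O`: 61 nM
- compound 3 `CC(=O)N1CCc2c(C)c3c(n2-c2ccc(C(N)=O)c(c2)N[C@@H](C)[C@H](C)C1)CC(C)(C)CC3=O`: 24 nM

Compound 3 has the lowest number of the three in this assay, and its gaps to the other two lie beyond the usual scatter. The next compound, compound 4 `Cc1c2c(n3c1CCN(C(=O)[C@@H](N)C(C)C)C[C@@H](C)[C@H](C)Nc1cc-3ccc1C(N)=O)CC(C)(C)CC2=O`, keeps the same shared core and carries 1-amino-2-methylpropyl in place of methyl on a carbonyl carbon, the carbon bonded to an amide-type nitrogen in a ring: 1-amino-2-methylpropyl in place of methyl on a carbonyl carbon. In other words, acetyl gives way to (1-amino-2-methylpropyl)carbonyl.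

Among the measured compounds shown here, no measured step changes the group on this carbonyl carbon. The only one available, a 6.0-fold lower number from compound 1 to compound 2 (0.78 log units; beyond the scatter), is modest and concerns methyl in place of hydrogen on a saturated ring carbon, so it offers only a rough guide to size. A shift no larger than that is expected, leaning towards a higher number. The expected step is a 1.5-fold higher number from compound 3 to compound 4 (0.16 log units; within the scatter). Compound 4 is estimated at 35 nM, with an expected range of 11 nM to 110 nM.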

Compound 4, half-maximal inhibitory concentration: 48 nM
Compound 4: the middle estimate sits 1.4-fold (0.14 log units) below what was measured, and the stated range covers the measured number.
By their numbers in this assay, from the lowest: compounds 3, 4 and 2 (each within the scatter of the next, the first and the last beyond it); then compound 1.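

In this assay, the change on this carbonyl carbon, the one bonded to an amide-type nitrogen in a ring, gives a 2.0-fold higher number from compound 3 to compound 4 (0.30 log units; within the scatter) even though 1-amino-2-methylpropyl is far larger than methyl. The earlier compounds shown here showed only that acetyl could stand at this position; this step shows that a branched group carrying an amine and a defined stereocentre can stand there too, with the two numbers staying within the usual scatter of each other. Nothing measured here offers a reason for this result.

On these data alone, it remains open whether the amine in 1-amino-2-methylpropyl matters at all, or whether a plain isobutyl group would serve equally well. Also open, as far as these compounds go, are the opposite configuration at the new stereocentre and how a carboxylic acid or a longer chain on this carbonyl carbon would compare.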